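The source may hold more compounds than are shown below. What is called first, only, known or untested is meant among the compounds shown, and "the series" means these compounds.

Working notes on the series. In a functional assay on MDA-MB-231 cells (Homo sapiens) for cytotoxicity, read by MTT assay, with a stated time of 72 h (on this read-out lower numbers stand for stronger inhibition and higher numbers for weaker inhibition), compound 3 `FC(F)(F)c1ccc(CSc2nc(Nc3ccc(C(F)(F)F)cc3)c3ccccc3n2)cc1` gives 5460 nM, the lowest number of the three measured compounds; compound 2 `O=[N+]([O-])c1ccc(Nc2nc(SCc3ccc(C(F)(F)F)cc3)nc3ccccc23)cc1` gives 8670 nM and compound 1 `O=[N+]([O-])c1cccc(Nc2nc(SCc3ccc(C(F)(F)F)cc3)nc3ccccc23)c1` gives 31500 nM. The step of a 5.8-fold lower number from compound 1 to compound 3 (0.76 log units; beyond the scatter) and the step of a 3.6-fold lower number from compound 1 to compound 2 (0.56 log units; beyond the scatter) both move the substituent on the aniline ring; the step of a 1.6-fold lower number from compound 2 to compound 3 (0.20 log units; within the scatter) swaps one para group for another and is within the scatter. Compound 4 `COc1ccc(Nc2nc(SCc3ccc(C(F)(F)F)cc3)nc3ccccc23)cc1` carries methoxy in place of trifluoromethyl on an aromatic carbon. For the measured compounds named here, the only swap of a para group on record, from compound 2 to compound 3, stayed within the scatter, and nothing on record covers methoxy. A step within the scatter or a small rise is therefore expected, a 1.4-fold higher number from compound 3 to compound 4 (0.14 log units; within the scatter). Compound 4 is estimated at 7500 nM in this assay, in the range 2500 nM to 22000 nM.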

Compound 4, half-maximal inhibitory concentration: 15700 nM
Compound 4: middle estimate off by 2.1-fold (0.32 log units), on the low side; measured number inside the range.
By their numbers in this assay, from the lowest: compounds 3, 2, 4 and 1 (each within the scatter of the next, the first and the last beyond it).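

In this assay, the change of group at this aromatic carbon now has a readable effect: trifluoromethyl to methoxy gives a 2.9-fold higher number from compound 3 to compound 4 (0.46 log units; beyond the scatter), whereas the earlier swap of nitro for trifluoromethyl stayed within the scatter. Methoxy is not separated from nitro, with a 1.8-fold higher number from compound 2 to compound 4 (0.26 log units; within the scatter), nor is 4-methoxyphenyl separated from 3-nitrophenyl, with a 2.0-fold lower number from compound 1 to compound 4 (0.30 log units; within the scatter), both within the scatter. No measurement here accounts for the step away from trifluoromethyl. Going by these compounds, whether an amine, a chlorine or a longer alkoxy chain at this carbon would stay near compound 3 or compound 4 remains open.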